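This account rests on a few compounds, and the source may have more. Where it says the series, first, only, none or still open, it means among the compounds named here.

Three compounds share one core and differ in a single group on an aromatic carbon. Compound 1 `CCc1cc(C)c(C(=O)N=C(N)N)cc1S(C)(=O)=O` carries ethyl there, and in a functional assay for inhibition of sodium/hydrogen exchanger (Oryctolagus cuniculus) (a higher number here means a weaker inhibitor, a lower number a stronger inhibitor), compound 1 gives 4.8 nM. Compound 2 `CCCSc1cc(C)c(C(=O)N=C(N)N)cc1S(C)(=O)=O` carries propylsulfanyl, and in this assay compound 2 gives 6.8 nM; the step of a 1.4-fold higher number from compound 1 to compound 2 (0.15 log units; within the scatter) lies within the scatter. Compound 3 `Cc1cc(OC2CCCC2)c(S(C)(=O)=O)cc1C(=O)N=C(N)N` carries cyclopentyloxy, and in this assay compound 3 gives 27 nM, the highest of the three numbers, with a 5.6-fold higher number from compound 1 to compound 3 (0.75 log units; beyond the scatter) and a 4.0-fold higher number from compound 2 to compound 3 (0.60 log units; beyond the scatter) both beyond the scatter.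

The next compound, compound 4 `Cc1cc(Oc2cncc(Cl)c2)c(S(C)(=O)=O)cc1C(=O)N=C(N)N`, keeps the oxygen of compound 3 and changes what sits on it: 5-chloropyridin-3-yl in place of cyclopentyl on an oxygen on an aromatic ring

For the measured compounds named here, the two measured steps that end in compound 3 show only that a cyclopentyloxy group gives a higher number than a short chain; neither tests an aromatic ring on the oxygen, so no measured step bears directly on this change. The expectation therefore leans on compound 3 alone, with wide uncertainty and no clear direction. In this assay compound 4 is expected to give about 35 nM, between 8 nM and 150 nM, which means an expected step of a 1.3-fold higher number from compound 3 to compound 4 (0.11 log units; within the scatter) that may well stay within the scatter.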

Compound 4, half-maximal inhibitory concentration: 14 nM
For compound 4 the middle estimate is 2.5-fold (0.40 log units) above the measured one; the range from low to high includes it.
By their numbers in this assay, from the lowest: compounds 1 and 2 (each within the scatter of the next); then compounds 4 and 3 (each within the scatter of the next).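

For the compounds shown here, replacing cyclopentyl with 5-chloropyridin-3-yl puts an aromatic ring on this oxygen for the first time, and the result in this assay is a step of (a 1.9-fold lower number from compound 3 to compound 4 (0.29 log units; within the scatter)). The new group has more heavy atoms, a ring nitrogen, a chlorine and a hydrogen-bond acceptor, yet compound 3 and compound 4 cannot be told apart in this measurement, so a saturated ring and this aromatic ring read alike here. Compound 4 also stays apart from the two compounds without an oxygen at this position, with modest steps of (a 2.1-fold higher number from compound 2 to compound 4 (0.31 log units; beyond the scatter)) and (a 2.9-fold higher number from compound 1 to compound 4 (0.46 log units; beyond the scatter)), and nothing available explains these differences.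

Going by these compounds alone, with only one aromatic group on the oxygen, the separate contributions of its ring nitrogen and its chlorine remain open. Going by these compounds, it is also open how this assay would read for a plain phenyl group on the oxygen, or for an amine in place of the oxygen on the aromatic carbon.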